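The source may report more compounds than this note shows. Statements on the series, on what has been measured and on what is new or still open speak of the compounds shown alone.

Measured compounds and their numbers in an assay on isolated protein for binding affinity to Type-2 angiotensin II receptor (Homo sapiens); on this read-out higher numbers stand for weaker inhibition and lower numbers for stronger inhibition:
compound 1, `CCCc1nc(CC)c(C(=O)OCc2ccccc2OC)n1Cc1ccc(-c2ccccc2S(=O)(=O)NC(=O)OCCC(C)C)cc1F`, gives 1 nM
compound 2, `CCCc1nc(CC)c(C(=O)OCc2ccccc2OCCC(C)C)n1Cc1ccc(-c2ccccc2S(=O)(=O)NC(=O)OCCC(C)C)cc1F`, gives 10 nM
compound 3, `CCCc1nc(CC)c(C(=O)OCc2ccccc2NC(=O)c2ccccc2)n1Cc1ccc(-c2ccccc2S(=O)(=O)NC(=O)OCCC(C)C)cc1F`, gives 1 nM

Compound 3 stands level with compound 1 at the digits shown, and the two together hold the lowest numbers of the three; compound 2 sits furthest from them, the step of a 10-fold lower number from compound 2 to compound 3 (1.00 log units; beyond the scatter) being beyond the usual scatter, whereas no change at the digits printed from compound 1 to compound 3 (within the scatter) lies within it.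

Compound 4, `CCCc1nc(CC)c(C(=O)OCc2ccccc2-c2ccccc2)n1Cc1ccc(-c2ccccc2S(=O)(=O)NC(=O)OCCC(C)C)cc1F`, has not yet been measured. The change that leads to it is phenyl in place of benzamido on an aromatic carbon. Within the data shown here, two measured steps bear on it: both alter the group on the same aromatic carbon of the shared core. The step of no change at the digits printed from compound 1 to compound 3 (within the scatter) shows that exchanging methoxy for benzamido leaves the number where it was, while a 10-fold higher number from compound 1 to compound 2 (1.00 log units; beyond the scatter) and a 10-fold lower number from compound 2 to compound 3 (1.00 log units; beyond the scatter) show that the larger isopentyloxy group moves the number by a modest amount in the weaker direction. Phenyl is a group of intermediate size at this place, so the step of a 2.0-fold higher number from compound 3 to compound 4 (0.30 log units; within the scatter) is expected to be small, most likely within the scatter or slightly in the weaker direction. In this assay compound 4 is therefore estimated at 2 nM, with a range from 0.5 nM to 10 nM.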

Compound 4, half-maximal inhibitory concentration: 9 nM
Compound 4: the middle estimate sits 4.5-fold (0.65 log units) below what was measured; measured number inside the range.
By their numbers in this assay, from the lowest: compounds 1 and 3 (each within the scatter of the next); then compounds 4 and 2 (each within the scatter of the next).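

In this assay the exchange of benzamido for phenyl on this aromatic carbon, ortho to a large group, gives a 9.0-fold higher number from compound 3 to compound 4 (0.95 log units; beyond the scatter) and so shows that a six-membered aromatic ring of carbon at this place does not by itself hold the low number seen with benzamido. Phenyl also gives a 9.0-fold higher number from compound 1 to compound 4 (0.95 log units; beyond the scatter) when set against methoxy and a 1.1-fold lower number from compound 2 to compound 4 (0.05 log units; within the scatter) when set against isopentyloxy, so it falls with isopentyloxy and apart from methoxy and benzamido, and a plain rule that more heavy atoms give a higher number fails here, with compound 3 going against it: benzamido with 9 heavy atoms stands level with methoxy, while phenyl with 6 does not. Nothing measured here accounts for this result.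

What leaves with benzamido is the amide hydrogen and the carbonyl together, and the compounds shown cannot tell which of the two, if either, matters for the number. On these data alone, a benzyl ether, a benzylamine or an acetamido group at this place would separate these parts, and whether the same order of groups holds on any other core remains open.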